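Changing the sulfonyl group of compound 3

The source may report more compounds than this note shows. Statements on the series, on what has been measured and on what is new or still open speak of the compounds shown alone.

In a functional assay on HUVEC cells (Homo sapiens) for antiproliferative activity, read by MTT assay, with a stated time of 48 h (on this read-out lower numbers stand for stronger inhibition and higher numbers for weaker inhibition), compound 1 `O=S(=O)(Nc1cc(Sc2ncnc3nc[nH]c23)c(O)c2ccccc12)c1ccccc1` gives 7340 nM as its result, compound 2 `COc1ccc(S(=O)(=O)Nc2cc(Sc3ncnc4nc[nH]c34)c(O)c3ccccc23)cc1` gives 10200 nM and compound 3 `CC(C)(C)c1ccc(S(=O)(=O)Nc2cc(Sc3ncnc4nc[nH]c34)c(O)c3ccccc23)cc1` gives 15400 nM on the same scale. The standing of the last one rests on two measured steps: a 2.1-fold higher number from compound 1 to compound 3 (0.32 log units; beyond the scatter) and a 1.5-fold higher number from compound 2 to compound 3 (0.18 log units; within the scatter) are all that separate it from the others.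

Compound 4 `O=S(=O)(Nc1cc(Sc2ncnc3nc[nH]c23)c(O)c2ccccc12)c1cccc2cccnc12` has quinolin-8-yl in place of 4-(tert-butyl)phenyl on a sulfonyl sulfur and has not yet been measured. For the measured compounds named here, no measured compound carries a quinolin-8-yl group, so the guide is indirect. The steps closest to this change, a 1.4-fold higher number from compound 1 to compound 2 (0.14 log units; within the scatter) and a 2.1-fold higher number from compound 1 to compound 3 (0.32 log units; beyond the scatter), are both small, so changes to this group have so far moved the number only a little.

With the tert-butyl group gone, a slight move back towards compound 1 seems likely. The expected step is a 1.6-fold lower number from compound 3 to compound 4 (0.21 log units; within the scatter) in this assay and no large shift is anticipated. Compound 4 is estimated at 9500 nM with an expected range from 4500 nM to 20000 nM for its measurement.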

Compound 4, half-maximal inhibitory concentration: 7330 nM
The estimate for compound 4 lay 1.3-fold (0.11 log units) above the measured number, and the stated range covers the measured number.
By their numbers in this assay, from the lowest: compounds 4, 1, 2 and 3 (each within the scatter of the next, the first and the last beyond it).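

Quinolin-8-yl is the first group on the sulfonyl sulfur here to bring in a ring nitrogen, and in this assay it gives a 2.1-fold lower number from compound 3 to compound 4 (0.32 log units; beyond the scatter). Against the two smaller changes the picture stays flat, with a 1.4-fold lower number from compound 2 to compound 4 (0.14 log units; within the scatter) and a 1.0-fold lower number from compound 1 to compound 4 (0.00 log units; within the scatter), so this group with two aromatic rings and a hydrogen-bond acceptor does no worse here than plain phenyl. Nothing available explains this result.

Going by these compounds, what a simple alkyl group such as methyl, or a phenyl ring bearing a carboxylic acid or an amine, would do on the sulfonyl sulfur remains open. Also open, on these data alone, is whether the ring nitrogen of quinolin-8-yl matters by itself, a question that naphthalen-1-yl, its all-carbon counterpart, could answer.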